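Nitro Substitution on the Aryl Ring of Compound 1

A few compounds are considered here, and "the series" means these few. Any claim that something is new, unique, unknown or untested is made for them only; others in the source may bear on it.

Measured compounds:
compound 1 `COc1ccc2c(c1)OC(N)=C(C#N)C2c1ccccc1` — 360000000 nM
compound 2 `CCNc1ccc2c(c1)OC(N)=C(C#N)C2c1cc(OC)c(OC)c(OC)c1` — 49000000 nM
compound 3 `CCOc1ccc2c(c1)OC(N)=C(C#N)C2c1cc(Br)c(OC)c(OC)c1` — 64000000 nM

In a functional assay on T47D cells (Homo sapiens) for activation (on this read-out higher numbers stand for an effect only at larger amounts of compound and lower numbers for an effect already at smaller amounts), compound 1 stands highest of the three numbers. Compound 3 gives 64000000 nM and compound 2 gives 49000000 nM; both gaps to compound 1 lie beyond the scatter. Within the data shown here, no pair of measured compounds differs in only one place.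

Compound 4 `COc1ccc2c(c1)OC(N)=C(C#N)C2c1cccc([N+](=O)[O-])c1` differs from compound 1 by nitro in place of hydrogen on an aromatic carbon. The two measured compounds bearing further groups on that aromatic ring, compound 2 and compound 3, both sit below compound 1, so a moderate downward step is expected from compound 1 to compound 4, a 2.4-fold lower number from compound 1 to compound 4 (0.38 log units; beyond the scatter). Compound 4 is estimated at 150000000 nM, with a range from 40000000 nM to 500000000 nM.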

Compound 4, half-maximal effective concentration: 88900000 nM
For compound 4 the middle estimate is 1.7-fold (0.23 log units) above the measured one; the measured number falls inside the stated range.
By their numbers in this assay, from the lowest: compounds 2, 3 and 4 (each within the scatter of the next); then compound 1.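

In this assay, among these compounds, nitro in place of hydrogen on an aromatic carbon, meta to a large group, gives a 4.0-fold lower number from compound 1 to compound 4 (0.61 log units; beyond the scatter), the first change that can be read in one place. Among the compounds shown here, the earlier compounds differ from compound 1 in more than one place, so only this step shows that this single substitution lowers the number beyond the scatter. No measurement on hand explains the step.

As far as these compounds go, whether the step is specific to nitro remains open, as an amine or a carboxylic acid on the same carbon would test this. From the compounds shown here alone, the effect of nitro on the other carbons of that ring also remains open.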